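The source may hold more compounds than are shown below. What is called first, only, known or untested is meant among the compounds shown, and "the series" means these compounds.

Going by the values given here, two analogues of the shared core have numbers so far in a functional assay on RD cells (Homo sapiens) for inhibition, read by MTT assay, with a stated time of 72 h; on this read-out lower numbers stand for stronger inhibition and higher numbers for weaker inhibition. Compound 1 `CN1C(=O)N(C)C2C1NC(=S)N2/N=C/C=C/c1ccccc1` gives 46000 nM. Compound 2 `CCN1C(=O)N(CC)C2C1NC(=S)N2/N=C/C=C/c1ccccc1` gives 2250 nM, the lower of the two numbers; the gap between compound 1 and compound 2 lies beyond the scatter, so compound 2 stands as the stronger inhibitor of the pair. Compound 3 `CCN1C(=O)N(CC)C2C1NC(=S)N2/N=C/C=C/c1ccc(OC)cc1` is not yet measured in this assay. It differs from compound 2 by methoxy in place of hydrogen on an aromatic carbon. Among the compounds with values here, no measured pair shows a change of this kind, so no step can be read off for it, and the outcome for compound 3 rests only on the two numbers above. The expected step is a 1.3-fold lower number from compound 2 to compound 3 (0.10 log units; within the scatter), small, within the scatter, leaning if anything toward a lower number. Compound 3 is therefore estimated at 1800 nM, with a range from 600 nM to 6000 nM.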

Compound 3, half-maximal inhibitory concentration: 87000 nM
Compound 3: middle estimate off by 48-fold (1.68 log units), on the low side, outside the stated range (above it).
By their numbers in this assay, from the lowest: compound 2; then compounds 1 and 3 (each within the scatter of the next).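

In this assay, the change from phenyl to 4-methoxyphenyl gives a 39-fold higher number from compound 2 to compound 3 (1.59 log units; beyond the scatter), so this aromatic carbon, para to a large group, is not indifferent to substitution. The earlier pair left this ring unchanged and could not show this; here, methoxy in place of hydrogen is the only difference and is enough to weaken inhibition markedly. No available data explain why this substitution has so large an effect.

As far as these compounds go, it remains open whether the weakening is specific to methoxy or extends to other groups at this carbon, such as fluorine, methyl, hydroxyl or an amine. From the compounds shown here alone, it also remains open whether the same change has a similar effect with the methyl groups of compound 1 in place of the ethyl groups of compound 2.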